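A few compounds are considered here, and "the series" means these few. Any claim that something is new, unique, unknown or untested is made for them only; others in the source may bear on it.

Working notes on the series. Compound 1 `O=C(CNc1nc(N2CCCC2)nc2ccccc12)Nc1ccc2ccccc2c1` was measured in an ADME assay on HEK-293T cells (Homo sapiens) for cytotoxicity, read by CCK-8 assay, with a stated time of 48 h (a higher number here means that more compound is tolerated, a lower number that less compound is tolerated), and gives 59900 nM. Compound 2 `CCOc1ccc(NC(=O)CSc2c[nH]c3ccc(Br)cc23)cc1` in this assay gives 44000 nM; the two numbers lie within the scatter of each other, so compound 1 stands together with compound 2 rather than apart from it. Compound 3 `O=C(CNc1nc(N2CCCC2)nc2ccccc12)Nc1ccccc1` is not yet measured. It differs from compound 1 as follows: phenyl in place of naphthalen-2-yl on an amide-type nitrogen. Among the measured compounds shown here, no step between measured compounds is available to guide this change, so for compound 3 the step from compound 1 to compound 3 is expected to be small, at most a little toward more compound tolerated, and likely within the scatter: a 1.2-fold higher number from compound 1 to compound 3 (0.07 log units; within the scatter). For compound 3 the value in this assay is estimated at 70000 nM, ranging from 35000 nM to 140000 nM.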

Compound 3, half-maximal cytotoxic concentration: 23300 nM
Beside the measured number, compound 3's estimate is 3.0-fold (0.48 log units) above it; the measured number lies below the stated range.
By their numbers in this assay, from the lowest: compounds 3, 2 and 1 (each within the scatter of the next, the first and the last beyond it).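

Phenyl in place of naphthalen-2-yl on an amide-type nitrogen gives a 2.6-fold lower number from compound 1 to compound 3 (0.41 log units; beyond the scatter) in this assay and is the first step in the series that can be read. The group at this position therefore moves the number, with less compound tolerated for the single aromatic ring than for the two. No measurement at hand offers an explanation for this step. Open, going by these compounds, is how an amine or a carboxylic acid on the phenyl ring would shift the number. Also open, on these data alone, is whether a longer chain on this nitrogen would do the same.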